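This account rests on a few compounds, and the source may have more. Where it says the series, first, only, none or still open, it means among the compounds named here.

Working notes on the series. Among the measured compounds shown here, compound 1 `Cc1cc(C)c(NC(=O)N(Cc2cccc(-c3cc[nH]n3)c2)C2CCCCCC2)c(C)c1` is the one member with a full number: in a functional assay on a cell-free system (plasma) with sterol O-acyltransferase, Soat (Rattus norvegicus) as the target (a lower number here means that less compound is needed, a higher number that more compound is needed for the effect), compound 1 gives 0.097 mg/kg. Compound 2 `Cc1cc(C)c(NC(=O)N(Cc2cccc(-c3ccn(C)n3)c2)C2CCCCCC2)c(C)c1` differs from it by a methyl in place of hydrogen on an aromatic nitrogen. In this assay compound 2 is reported only as a limit, < 1 mg/kg. The step that the limit leaves unreadable from compound 1 to compound 2 therefore cannot be read, as the limit of < 1 mg/kg in this assay, at which 1 of the 2 values shown sits, shows; compound 2 stands somewhere under that limit and cannot be placed against compound 1 on the numbers shown.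

Compound 3 `Cc1cc(C)c(NC(=O)N(Cc2cccc(-c3ccnn3C)c2)C2CCCCCC2)c(C)c1` differs from compound 2 by 1-methyl-1H-pyrazol-5-yl in place of 1-methyl-1H-pyrazol-3-yl on an aromatic carbon. For the measured compounds named here, only one measured step exists, and its size is not readable, so no measured step bears on a change of this kind. The change keeps the same atoms and alters only how they are joined; with nothing measured to weigh it, the expectation for this assay is a step of unknown direction, taken as none beyond the scatter: a step that the limit leaves unreadable from compound 2 to compound 3. Compound 3 is accordingly estimated at 0.3 mg/kg, with a range from 0.05 mg/kg to 2 mg/kg.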

Compound 3, dose for half-maximal effect: > 1 mg/kg
Compound 3: a limit, no number; the forecaster's own chance of this, stated with the estimate: 50%; middle value at least 3.3-fold (0.52 log units) away from the limit.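

In this assay, among the compounds shown here, the first readable step is an at least 10-fold higher number from compound 1 to compound 3 (1.01 log units; beyond the scatter), with 1-methyl-1H-pyrazol-5-yl in place of 1H-pyrazol-3-yl on an aromatic carbon. Compound 3 is reported only as a limit, > 1 mg/kg, so the step marks a real loss for this replacement at this place on the ring, though its full size stays open and the numbers give no reason for it. With 1-methyl-1H-pyrazol-5-yl in place of 1-methyl-1H-pyrazol-3-yl on an aromatic carbon, the data give a number no lower from compound 2 to compound 3 (the limit leaves the size open). That step and the step leading into compound 2 cannot be read, so the two isomeric methylpyrazoles cannot be ordered against each other on the numbers, and the limit on the new compound is part of what stands in the way: the limit of > 1 mg/kg in this assay, at which 1 of the 3 values shown sits.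

The compounds shown leave open whether the methyl on the aromatic nitrogen, its placement in the ring, or both together carry the step seen with compound 3. They also leave open how this place on the core of compound 1 would respond to a quite different group, such as an amine or a carboxylic acid in place of the pyrazole.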